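Adding a Dichlorophenylsulfonyl Group to Compound 3

The source may report more compounds than this note shows. Statements on the series, on what has been measured and on what is new or still open speak of the compounds shown alone.

Compound 3 `COC(=O)c1ccc(C2SCC(=O)N2c2ccc(N3CCNCC3)cn2)c(OC)c1` carries a free amine nitrogen in a ring on the shared core. In a functional assay on K562 cells (Homo sapiens) for antiproliferative activity, read by MTT assay and trypan blue exclusion, with a stated time of 72 h (a higher number here means a weaker inhibitor, a lower number a stronger inhibitor), compound 3 gives 15200 nM, the lowest number among the measured compounds. Compound 2 `COC(=O)c1ccc(C2SCC(=O)N2c2ccc(N3CCN(S(=O)(=O)c4ccccc4)CC3)cn2)c(OC)c1` bears a phenylsulfonyl on that nitrogen and gives 65600 nM. Compound 1 `COC(=O)c1ccc(C2SCC(=O)N2c2ccc(N3CCN(Cc4ccc(Cl)c(Cl)c4)CC3)cn2)c(OC)c1` bears a 3,4-dichlorobenzyl there, and its result is a limit of the assay, > 100000 nM. Both substituted compounds give higher numbers than compound 3: a 4.3-fold lower number from compound 2 to compound 3 (0.64 log units; beyond the scatter), and an at least 6.5-fold lower number from compound 1 to compound 3 (0.81 log units; beyond the scatter). Compound 4 `COC(=O)c1ccc(C2SCC(=O)N2c2ccc(N3CCN(S(=O)(=O)c4cc(Cl)ccc4Cl)CC3)cn2)c(OC)c1` differs from compound 3 in one place: (2,5-dichlorophenyl)sulfonyl in place of hydrogen on an amine nitrogen in a ring. The step of a 4.3-fold lower number from compound 2 to compound 3 (0.64 log units; beyond the scatter) bears most directly, read in reverse, so a modest rise is expected, a 4.6-fold higher number from compound 3 to compound 4 (0.66 log units; beyond the scatter). Compound 4 is accordingly estimated at 70000 nM, within 25000 nM to 200000 nM.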

Compound 4, half-maximal inhibitory concentration: > 100000 nM
Compound 4 was reported as a limit; the forecaster's own chance of this, stated with the estimate: 35%; middle value at least 1.4-fold (0.15 log units) from the limit.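

On the free amine nitrogen, a (2,5-dichlorophenyl)sulfonyl group gives an at least 6.5-fold higher number from compound 3 to compound 4 (0.81 log units; beyond the scatter) in this assay, so all three substituents shown on this nitrogen give higher numbers than hydrogen. Placing the two chlorines on the phenyl of the sulfonyl group gives an at least 1.5-fold higher number from compound 2 to compound 4 (0.18 log units; that floor lies within the scatter), so no effect of the chlorines can be claimed. Compound 1 and compound 4 are both reported only as limits, so the step between them cannot be read: the limit of > 100000 nM in this assay, at which 2 of the 4 values shown sit.

From the compounds shown here alone, whether a small group on this nitrogen, such as methyl or acetyl, would keep the number near that of compound 3 remains open.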